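The source may report more compounds than this note shows. Statements on the series, on what has been measured and on what is new or still open speak of the compounds shown alone.

Working notes on the series:

- compound 1 `Nc1ccccc1NC(=O)c1ccc(NC(=S)NCc2ccc(Cl)nc2)cc1` gives 6100 nM
- compound 2 `Nc1ccccc1NC(=O)c1ccc(NC(=O)NCc2ccc(Cl)nc2)cc1` gives 5200 nM
- compound 3 `Nc1ccccc1NC(=O)c1ccc(NC(=S)NCc2cncc(Br)c2)cc1` has not been measured

In a functional assay on HCT-116 cells (Homo sapiens) for cytotoxicity, read by MTT assay, with a stated time of 72 h (on this read-out higher numbers stand for weaker inhibition and lower numbers for stronger inhibition), compound 1 stands at 6100 nM and compound 2 at 5200 nM and the two lie within the scatter of each other. Compound 3 departs from compound 1 by one change (5-bromopyridin-3-yl in place of 6-chloropyridin-3-yl on a saturated chain carbon bound to an amide-type nitrogen) with 5-bromopyridin-3-yl in place of 6-chloropyridin-3-yl on a saturated chain carbon bound to an amide-type nitrogen. Within the data shown here, no measured step covers this exchange, so no shift beyond the scatter is expected in this assay and no direction is favoured. The estimated step is a 1.1-fold lower number from compound 1 to compound 3 (0.04 log units; within the scatter) and it rests on very little data. Compound 3 is expected at 5500 nM with an estimated range from 2500 nM to 12000 nM for now.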

Compound 3, half-maximal inhibitory concentration: 9200 nM
Compound 3: the middle estimate sits 1.7-fold (0.22 log units) below what was measured, within the range that was stated.
By their numbers in this assay, from the lowest: compounds 2, 1 and 3 (each within the scatter of the next).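

In this assay, among these compounds, the exchange of 6-chloropyridin-3-yl for 5-bromopyridin-3-yl on a saturated chain carbon bound to an amide-type nitrogen gives a 1.5-fold higher number from compound 1 to compound 3 (0.18 log units; within the scatter) and is the first step read at this place. This read-out therefore does not tell the two groups apart, and the place accepts either one without a shift beyond the scatter. No supporting data bear on this result.

Open, from the compounds shown here alone, is whether an amine or a carboxylic acid on the pyridine ring, or a longer chain in place of the methyl link, would move the number beyond the scatter.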